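The source may hold more compounds than are shown below. What is called first, only, known or untested is meant among the compounds shown, and "the series" means these compounds.

Compound 1 `C=CC(=C)[C@@H](C[C@H]1C(=C)CC[C@H]2[C@](C)(CO)CCC[C@]12C)OO` and compound 2 `C=CC(=C)[C@@H](C[C@H]1C(=C)CC[C@@H]2[C@]1(C)CCC[C@@]2(C)C(=O)O)OO` both carry a hydroperoxide on a chain attached to a shared core. In a functional assay on PC-3 cells (Homo sapiens) for inhibition, read by colorimetric assay and MTT assay (a higher number here means a weaker inhibitor of growth, a lower number a stronger inhibitor of growth), compound 1 gives 34400 nM, and compound 2 gives 38000 nM; the step of a 1.1-fold higher number from compound 1 to compound 2 (0.04 log units; within the scatter) shows the two sitting within the scatter of each other, so neither stands apart. Compound 3 `C=CC(=C)[C@H](C[C@H]1C(=C)CC[C@@H]2[C@]1(C)CCC[C@@]2(C)C(=O)O)OO` differs from compound 2 only as follows: the two compounds have the same atoms and bonds and differ only in configuration as drawn: 1 of 5 stereo elements differ; a stereocentre at a saturated chain carbon is drawn R in compound 2 and S in compound 3. No measured step involves a change of configuration, so nothing shown speaks to its effect. The expectation is therefore a step of no change at the digits printed from compound 2 to compound 3 (within the scatter), and compound 3 is estimated at 38000 nM, ranging from 15000 nM to 95000 nM.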

Compound 3, concentration for 50% growth inhibition: > 100000 nM
Compound 3: a limit, no number; the forecaster's own chance of this, stated with the estimate: 5%; middle value at least 2.6-fold (0.42 log units) from the limit.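

Changing only the configuration at this saturated chain carbon, from R to S, gives an at least 2.6-fold higher number from compound 2 to compound 3 (0.42 log units; beyond the scatter). The step can be traced to configuration alone because of one fact: the fact that compounds 2 and 3 differ only in the configuration as drawn. The reading for compound 3 is a limit of the assay and not a number: the limit of > 100000 nM in this assay, at which 1 of the 3 values shown sits.

As far as these compounds go, the S configuration appears here only with the carboxy group, so its effect alongside the hydroxymethyl group of compound 1 remains open. Also open, from the compounds shown here alone, is what a methyl ester in place of the carboxy group would do in either configuration.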